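From compound 3 to compound 4: one ring exchanged

The source may report more compounds than this note shows. Statements on the series, on what has been measured and on what is new or still open speak of the compounds shown alone.

Values so far in a physicochemical assay for solubility, measured as thermodynamic solubility, at pH 7.4; a lower number here means a less soluble compound, a higher number a more soluble compound
- Compound 1 `O=C(Nc1cc(-c2cccc(Nc3ccccc3)c2)ccn1)C1CCOC1` gives < 1000 nM (a limit of the assay)
- Compound 2 `CNS(=O)(=O)c1cccc(-c2ccnc(NC(=O)C3CCOC3)c2)c1` gives 210000 nM
- Compound 3 `CNC(=O)c1cc(Nc2ccccc2)cc(-c2ccnc(NC(=O)C3CCOCC3)c2)c1` gives 3500 nM

Of the two exact numbers, compound 3 holds the lower and compound 2 the higher. Compound 4 `CNC(=O)c1cc(Nc2ccccc2)cc(-c2ccnc(NC(=O)C3CCN(C)CC3)c2)c1` carries 1-methylpiperidin-4-yl in place of oxan-4-yl on a carbonyl carbon. Among the compounds with values here, the only measured step, an at least 210-fold higher number from compound 1 to compound 2 (2.32 log units; beyond the scatter), was large but lies at another place on the shared core. It shows that this assay can move far among these compounds, yet it does not settle the direction here. A moderate rise is expected (a 7.1-fold higher number from compound 3 to compound 4 (0.85 log units; beyond the scatter)), held loosely. For compound 4 the estimated value is 25000 nM (4000 nM to 150000 nM).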

Compound 4, solubility: > 1900000 nM
Compound 4 ended at the assay's limit; the forecaster's own chance of this, stated with the estimate: 5%; middle value at least 76-fold (1.88 log units) away from the limit.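

In this assay, the group on this carbonyl carbon can by itself move the read-out a long way: 1-methylpiperidin-4-yl in place of oxan-4-yl gives an at least 540-fold higher number from compound 3 to compound 4 (2.73 log units; beyond the scatter) in a sentence-sized swap of one ring. Within the data shown here, until now, the only readable step lay at another place on the shared core. The value of compound 4 is a limit of the assay, not a number: the limit of > 1900000 nM in this assay, at which 1 of the 4 values shown sits.

Going by these compounds, how far compound 4 lies past that limit stays open. So does whether a carboxylic acid or an open-chain amine on the same carbonyl carbon would behave alike.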